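Metabolic stability of two tetrazole ethers and a carboxyphenyl analogue

The compounds below may be only part of what the source reports. "The series", "measured", "known", "first", "only" and "open" are said of these compounds alone.

Compound 1: `CCCCCCCCc1ccc(OCC(=O)Cn2nnc(SC)n2)cc1` gives < 5% in an ADME assay on S9 fraction from liver (Rattus norvegicus) for metabolic stability, read by LC-MS, using NADPH, with a stated time of 30 min; on this read-out lower numbers stand for a less stable compound and higher numbers for a more stable compound. Compound 2: `CCCCCCCCc1ccc(OCC(=O)Cn2nnc(-c3cccc(S(=O)(=O)N(C)C)c3)n2)cc1` gives 9% in this assay.

The value for compound 1 in this assay is a limit, not a number, (the limit of < 5% in this assay, at which 1 of the 2 values shown sits). Compound 2 holds the only number shown; the other value is a limit. For the measured compounds named here, the step of a number at least 4 percentage points higher from compound 1 to compound 2 (that floor lies within the scatter) is the one measured step. Compound 3 is `CCCCCCCCc1ccc(OCC(=O)Cn2nnc(-c3ccc(C(=O)O)cc3)n2)cc1`, differing from compound 2 by 4-carboxyphenyl in place of 3-(dimethylsulfamoyl)phenyl on an aromatic carbon. Since the lone measured step lies within the scatter, no step beyond the scatter is expected from compound 2 to compound 3 in this assay, a number 1 percentage points higher from compound 2 to compound 3 (within the scatter). Compound 3 is therefore expected to give about 10%, between 0% and 25%.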

Compound 3, percent of the compound remaining: < 5%
Compound 3: only a limit was reported; the forecaster's own chance of this, stated with the estimate: 35%; middle value at least 5 percentage points from the limit.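

In this assay, 4-carboxyphenyl in place of 3-(dimethylsulfamoyl)phenyl gives a number at least 4 percentage points lower from compound 2 to compound 3 (that floor lies within the scatter), so this position still shows no step beyond the scatter, now with a second aryl group in place. Compound 3 gives a limit, not a number, and it joins compound 1 there: the limit of < 5% in this assay, at which 2 of the 3 values shown sit.

The step from compound 1 to compound 3 cannot be read, as both values are limits. As far as these compounds go, whether an aminophenyl group in this place, or a shorter chain in place of the octyl chain on the shared core, would give a step beyond the scatter stays open.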